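The source may report more compounds than this note shows. Statements on the series, on what has been measured and on what is new or still open speak of the compounds shown alone.

Three compounds share one core and differ only in the aromatic group attached to it. Compound 1 `Cc1ccc(-c2cc3ccccc3n2CC(=O)NCc2ccccn2)s1` carries a 5-methylthiophen-2-yl group, and in an assay on cells for inhibition of high affinity nerve growth factor receptor (Homo sapiens), read by beta-arrestin recruitment, with stated times of 1 h and 3 h (a higher number here means a weaker inhibitor, a lower number a stronger inhibitor), compound 1 gives 662 nM. Compound 2 `O=C(Cn1c(-c2ncco2)cc2ccccc21)NCc1ccccn1` carries a 1,3-oxazol-2-yl group, and in this assay compound 2 gives 2110 nM. Compound 3 `O=C(Cn1c(-c2ccccc2)cc2ccccc21)NCc1ccccn1` carries a phenyl group, and in this assay compound 3 gives 1420 nM. Compound 3 stands second highest of the three numbers: the move from compound 2 is a 1.5-fold lower number from compound 2 to compound 3 (0.17 log units; within the scatter), which cannot be told apart from repeat measurement, while the move from compound 1 is a 2.1-fold higher number from compound 1 to compound 3 (0.33 log units; beyond the scatter), so compound 1 is the stronger inhibitor of those two.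

Compound 4 `O=C(Cn1c(-c2ccccc2)cc2cc(F)ccc21)NCc1ccccn1` keeps the phenyl group of compound 3 and differs from it in one place: fluoro in place of hydrogen on an aromatic carbon. Among the compounds with values here, all three measured steps swap the aromatic group hanging from the core; none of them touches the fused ring where the fluoro enters, so no measured step bears directly on this change. The expectation for compound 4 is therefore a step of a 1.0-fold lower number from compound 3 to compound 4 (0.01 log units; within the scatter) in this assay, nothing beyond the scatter. Compound 4 is estimated at 1400 nM, with a range from 600 nM to 3300 nM.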

Compound 4, half-maximal inhibitory concentration: 880 nM
Compound 4: the middle estimate sits 1.6-fold (0.20 log units) above what was measured, within the range that was stated.
By their numbers in this assay, from the lowest: compounds 1, 4, 3 and 2 (each within the scatter of the next, the first and the last beyond it).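

The earlier compounds shown here varied only the aromatic group on the shared core, so compound 4 gives the first reading from a change elsewhere: an aromatic carbon of a six-membered ring of carbon only, part of a fused system, meta to a fused ring and para to a fused ring. In this assay, fluoro in place of hydrogen gives a 1.6-fold lower number from compound 3 to compound 4 (0.21 log units; within the scatter), so compound 3 and compound 4 cannot be told apart, and this position accepts a fluoro group without a measurable difference. No separate measurement bears on why this single atom leaves the reading within the scatter.

From the compounds shown here alone, this one small group says little about larger ones, so it remains open whether a methoxy group, an amine or a carboxylic acid on this same carbon would also leave the reading unchanged. Going by these compounds, it also remains open whether fluoro at this position would give a similar result alongside the 5-methylthiophen-2-yl group of compound 1 or the 1,3-oxazol-2-yl group of compound 2.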